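The source may hold more compounds than are shown below. What is called first, only, known or untested is meant among the compounds shown, and "the series" means these compounds.

Measured so far in a functional assay on PC-3 cells (Homo sapiens) for cytotoxicity, read by MTT assay, with a stated time of 72 h; on this read-out lower numbers stand for stronger inhibition and higher numbers for weaker inhibition:
compound 1 `COc1ccc(-c2cc(C(=O)Nc3ccc(Oc4ccnc5[nH]ccc45)cc3)ncn2)cc1` gives 9830 nM;
compound 2 `O=C(Nc1ccc(Oc2ccnc3[nH]ccc23)cc1)c1cc(-c2ccc(Cl)cc2)ncn1` gives 15600 nM;
compound 3 `O=C(Nc1ccc(Oc2ccnc3[nH]ccc23)cc1)c1cc(-c2ccc(Br)cc2)ncn1` gives 2610 nM.

Compound 2 sits at the high end of these numbers: the step from compound 1 to compound 2 a 1.6-fold higher number from compound 1 to compound 2 (0.20 log units; within the scatter) stays within the scatter, whereas the step from compound 2 to compound 3 a 6.0-fold lower number from compound 2 to compound 3 (0.78 log units; beyond the scatter) lies beyond it.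

Compound 4 `O=C(Nc1ccc(Oc2ccnc3[nH]ccc23)c(F)c1)c1cc(-c2ccc(Cl)cc2)ncn1` differs from compound 2 by fluoro in place of hydrogen on an aromatic carbon. None of the three measured steps touches this ring; they all swap the group on the other aromatic ring, so nothing measured bears directly on this change. With no guide, the expected step from compound 2 to compound 4 a 1.2-fold lower number from compound 2 to compound 4 (0.08 log units; within the scatter) is none beyond the scatter. Compound 4 is therefore estimated at 13000 nM, in a range from 4000 nM to 40000 nM.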

Compound 4, half-maximal inhibitory concentration: 3200 nM
The estimate for compound 4 lay 4.1-fold (0.61 log units) above the measured number; measured number below the stated range.
By their numbers in this assay, from the lowest: compounds 3 and 4 (each within the scatter of the next); then compounds 1 and 2 (each within the scatter of the next).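

In this assay the aromatic ring carrying the fluoro proves able to change the number, where all earlier steps swapped a group on the other aromatic ring. A single fluoro in place of hydrogen, ortho to one large group and meta to another, gives a 4.9-fold lower number from compound 2 to compound 4 (0.69 log units; beyond the scatter), so this small change moves the number beyond the scatter. Nothing available accounts for the size of this step.

As far as these compounds go, whether fluoro here acts the same way alongside the methoxy of compound 1 or the bromo of compound 3 remains open. So does the outcome with a methyl or an amine in its place.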